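A few compounds are considered here, and "the series" means these few. Any claim that something is new, unique, unknown or untested is made for them only; others in the source may bear on it.

Measured compounds and their values:

- compound 1, `O=c1oc2ccc(Cl)cc2c(=O)n1-c1ccc(I)cc1F`: 6900 nM
- compound 2, `O=c1oc2ccc(Cl)cc2c(=O)n1-c1ccc(Br)cc1F`: 8100 nM
- compound 3, `O=c1oc2ccc(Cl)cc2c(=O)n1-c1ccc(Cl)cc1F`: 6800 nM

All three values come from an ADME assay on RAW264.7 cells (Mus musculus) for cytotoxicity, read by MTT assay, with a stated time of 24 h; a lower number here means that less compound is tolerated, a higher number that more compound is tolerated. Within this small set, compound 1 stands second highest, yet its values against compound 2 and compound 3 sit so close that no order can be claimed among them: the steps of a 1.2-fold higher number from compound 1 to compound 2 (0.07 log units; within the scatter), a 1.0-fold lower number from compound 1 to compound 3 (0.01 log units; within the scatter) and a 1.2-fold lower number from compound 2 to compound 3 (0.08 log units; within the scatter) all fall inside the usual scatter of repeated runs.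

Compound 4, `O=c1oc2ccccc2c(=O)n1-c1ccc(I)cc1F`, differs from compound 1 at one place on the shared core: hydrogen in place of chloro on an aromatic carbon. Within the data shown here, none of the measured steps touches this place; each of them swaps one halogen for another on the other aromatic ring and leaves the chloro on the core untouched. They show that the measured values barely moved when that halogen was varied, but they say nothing direct about removing the chloro from the core.

Among the measured compounds shown here, with no step that bears on the change, the plainest expectation is that compound 4 stays near compound 1, with a step of a 1.0-fold higher number from compound 1 to compound 4 (0.01 log units; within the scatter) that lies within the scatter. Compound 4 is therefore estimated in this assay at 7000 nM, with a range from 3000 nM to 16000 nM.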

Compound 4, half-maximal cytotoxic concentration: 24500 nM
Compound 4: the middle estimate sits 3.5-fold (0.54 log units) below what was measured, outside the stated range (above it).
By their numbers in this assay, from the lowest: compounds 3, 1 and 2 (each within the scatter of the next); then compound 4.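

In this assay, replacing the chloro on an aromatic carbon of the shared core with hydrogen gives a 3.6-fold higher number from compound 1 to compound 4 (0.55 log units; beyond the scatter) and so, unlike the earlier halogen swaps, produces a modest step beyond the scatter, toward more compound being tolerated. Among the compounds shown, this position on the core therefore responds to a change, while the swaps among iodo, bromo and chloro on the other ring left compound 1, compound 2 and compound 3 within the scatter of one another. No measurement at hand gives a reason for this rise.

The compounds shown leave open whether another group at this place, such as a methoxy or an amine, would give a number closer to that of compound 4 or to that of compound 1. Hydrogen at this place also appears only with iodo on the other ring, so it remains open whether the same step would appear with bromo or chloro there.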